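Chalcone lactone amides: fluoro for isopropyl on the aryl ring

This account rests on a few compounds, and the source may have more. Where it says the series, first, only, none or still open, it means among the compounds named here.

Working notes on a small set of lactone-bearing compounds tested in a functional assay on MGC-803 cells (Homo sapiens) for antiproliferative activity, read by MTT assay, with a stated time of 72 h; a higher number here means a weaker inhibitor, a lower number a stronger inhibitor. Compound 1 `CC(C)c1ccc(/C=C/C(=O)c2ccc(OCC(=O)N[C@H]3CCOC3=O)cc2)cc1` gives 16800 nM in this assay, the lowest of the two numbers recorded, with compound 3 `C=CCc1ccc(OCCSC(=S)N[C@H]2CCOC2=O)c(OC)c1` the nearest at 27900 nM, a difference that lies within the scatter, so no order between the two is claimed. Compound 2 `O=C(CNc1cccc(Cl)c1)N[C@H]1CCOC1=O` returns only a limit in this assay, > 64000 nM, and not a number; the limit of > 64000 nM in this assay, at which 1 of the 3 values shown sits, marks where it sits.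

Compound 4 `O=C(COc1ccc(C(=O)/C=C/c2ccc(F)cc2)cc1)N[C@H]1CCOC1=O` is unmeasured. It differs from compound 1 by fluoro in place of isopropyl on an aromatic carbon. Among the measured compounds shown here, no step between two measured compounds with a change of this kind is available, so the size of the move must be judged from the change itself. Isopropyl and fluoro are both small, uncharged substituents on the same aromatic carbon, and the rest of the molecule is unchanged, so the expected step from compound 1 to compound 4 is a 1.2-fold higher number from compound 1 to compound 4 (0.08 log units; within the scatter), a shift not expected to exceed the scatter of this assay. Compound 4 is accordingly estimated at 20000 nM in this assay, with a range of 8000 nM to 50000 nM.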

Compound 4, half-maximal inhibitory concentration: > 64000 nM
Compound 4: a limit, no number (the forecaster's own chance of this, stated with the estimate: 15%); middle value at least 3.2-fold (0.50 log units) from the limit.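

Setting 4-fluorophenyl in place of 4-isopropylphenyl gives an at least 3.8-fold higher number from compound 1 to compound 4 (0.58 log units; beyond the scatter) in this assay, the only step in this set read at this position, so this aromatic carbon is not indifferent to the group it carries. Compound 4 returns a limit and not a number, so the size of the step has a floor but no measured end. Compound 4 now stands with compound 2 at the same limit: the limit of > 64000 nM in this assay, at which 2 of the 4 values shown sit.

Whether the change in this assay follows from the departure of isopropyl or the arrival of fluoro stays open, since only these two groups are shown on this carbon, and a methoxy, a tert-butyl or an amine there could separate the two readings. Whether the same exchange reads alike on any core other than that of compound 1 is also unknown.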